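Swapping Pyridin-3-yl for 5-Methylfuran-2-yl in Compound 4

This account rests on a few compounds, and the source may have more. Where it says the series, first, only, none or still open, it means among the compounds named here.

Of the compounds shown here, three sharing one core have been tested in an assay on Sf9 cells for inhibition of protein deacetylase HDAC6 (Homo sapiens), read by fluorescence, with a stated time of 40 min, tested at 100 nM; a lower number here means less inhibition, a higher number more inhibition at the concentration tested (going by the name of the read-out). Compound 1 `O=C(NO)c1ccc(NCc2nc(-c3cccnc3)nn2-c2ccccc2)cc1` gives 57.7%. Compound 2 `O=C(NO)c1ccc(NCc2nc(-c3ccccc3)nn2-c2ccc(F)cc2)cc1` gives 67.6%, and compound 3 `CC(C)c1ccc(-n2nc(-c3ccccc3)nc2CNc2ccc(C(=O)NO)cc2)cc1` gives 52.6%. Compound 1 lies within the scatter of both compound 2 and compound 3. Going by the values given here, the only single-point step known, a number 15 percentage points lower from compound 2 to compound 3 (beyond the scatter), alters a substituent elsewhere in the molecule, not the place changed here. Compound 4 `Cc1ccc(-c2nc(CNc3ccc(C(=O)NO)cc3)n(-c3ccccc3)n2)o1` differs from compound 1 by 5-methylfuran-2-yl in place of pyridin-3-yl on an aromatic carbon. Among the compounds with values here, no measured step touches that position, so the change is judged only against the spread of the three numbers, and compound 4 is expected to show no step beyond the scatter, a number 2.7 percentage points lower from compound 1 to compound 4 (within the scatter). Compound 4 is therefore estimated at 55%, with a range from 38% to 72%.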

Compound 4, a percentage reported as inhibition, at one concentration (the size of the read-out at that concentration, not a potency): 60.7%
For compound 4 the middle estimate is 5.7 percentage points below the measured one; low and high end bracket the measured number.
By their numbers in this assay, from the lowest: compounds 3, 1, 4 and 2 (each within the scatter of the next, the first and the last beyond it).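

In this assay, going by these compounds alone, the first step at this position, on the aromatic carbon between two ring nitrogen atoms, is a number 3 percentage points higher from compound 1 to compound 4 (within the scatter) and so stays within the scatter. A five-membered aromatic ring with oxygen, 5-methylfuran-2-yl, can therefore replace the six-membered pyridin-3-yl ring here with no step beyond the scatter at this single concentration. Nothing measured here explains this result. The compounds shown leave open whether an amine, a carboxylic acid or a longer chain at this position would give a step beyond the scatter.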